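From 4-bromophenyl to isobutyl on the shared core

The source may hold more compounds than are shown below. What is called first, only, known or untested is meant among the compounds shown, and "the series" means these compounds.

In a functional assay on CCRF-CEM cells (Homo sapiens) for antiproliferative activity, read by MTT assay, with a stated time of 48 h (on this read-out lower numbers stand for an effect already at smaller amounts and higher numbers for an effect only at larger amounts of compound), compound 1 `COC(=O)c1[nH]c2cc(OC)ccc2c1-c1ccc(Br)cc1` gives 330 nM and compound 2 `COC(=O)c1[nH]c2cc(OC)ccc2c1-c1ccc(Cl)c(Cl)c1` gives 580 nM, two values within the scatter of each other. Compound 3 `CCc1c(C(=O)OC)[nH]c2cc(OC)ccc12` reads > 100000 nM, which is a limit of the assay and not a number. Among the compounds with values here, compound 1 therefore stands level with compound 2, and only one other compound offers a comparison.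

Compound 4 `COC(=O)c1[nH]c2cc(OC)ccc2c1CC(C)C` has not yet been measured. It differs from compound 1 as follows: isobutyl in place of 4-bromophenyl on an aromatic carbon. In words, isobutyl takes the place of 4-bromophenyl on an aromatic carbon, and no ring enters with it.

Within the data shown here, one measured step bears on this change, with ethyl in place of 4-bromophenyl at the same carbon: an at least 300-fold higher number from compound 1 to compound 3 (2.48 log units; beyond the scatter). That large step ends at the limit of > 100000 nM in this assay, at which 1 of the 3 values shown sits, so compound 4 may likewise report only a limit. A similar move is expected here, with an estimated step of a 120-fold higher number from compound 1 to compound 4 (2.08 log units; beyond the scatter), large and towards higher numbers. For compound 4 the expected value is 40000 nM, with an estimated range of 6000 nM to 100000 nM.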

Compound 4, half-maximal effective concentration: 16600 nM
Compound 4: the middle estimate sits 2.4-fold (0.38 log units) above what was measured, and the stated range covers the measured number.
By their numbers in this assay, from the lowest: compounds 1 and 2 (each within the scatter of the next); then compound 4. At a limit, above all of these: compound 3.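

A chain without a ring at this carbon now has a readable number: in this assay, isobutyl in place of 4-bromophenyl gives a 50-fold higher number from compound 1 to compound 4 (1.70 log units; beyond the scatter), so the cost of losing the ring has a measured size and not only a bound. The make-up of the chain also matters, since isopropyl in place of methyl on the saturated chain carbon gives an at least 6.0-fold lower number from compound 3 to compound 4 (0.77 log units; beyond the scatter). The value of compound 3 in that step is a limit of the assay and not a number: the limit of > 100000 nM in this assay, at which 1 of the 4 values shown sits.

The compounds shown leave open whether a longer chain such as n-hexyl would bring the number down further. They also leave open whether a saturated ring such as cyclohexyl, or an unsubstituted phenyl, would come closer to compound 1.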